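The source may hold more compounds than are shown below. What is called first, only, known or untested is meant among the compounds shown, and "the series" means these compounds.

Measured so far:
compound 1, `CC(=O)OC[C@H]1O[C@@H](n2cc(CN3C(=O)/C(=C\c4ccc(N(C)C)cc4)c4ccccc43)nn2)[C@H](OC(C)=O)[C@@H](OC(C)=O)[C@@H]1OC(C)=O` — 29800 nM
compound 2, `CC(=O)OC[C@H]1O[C@@H](n2cc(CN3C(=O)/C(=C/c4ccc(N(C)C)cc4)c4ccccc43)nn2)[C@H](OC(C)=O)[C@@H](OC(C)=O)[C@@H]1OC(C)=O` — 25200 nM

Both were read in a functional assay on MCF7 cells (Homo sapiens) for cytotoxicity, read by sulforhodamine B assay, with a stated time of 48 h; a higher number here means a weaker inhibitor, a lower number a stronger inhibitor. Compound 2 has the lower of the two numbers in this assay, but its gap to compound 1 is within the scatter, so no order between the two is claimed. Among the compounds with values here, the only measured step, a 1.2-fold lower number from compound 1 to compound 2 (0.07 log units; within the scatter), rests on the fact that compounds 1 and 2 differ only in the configuration as drawn and not on any exchange of a substituent.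

Compound 3, `CCC/C=C1/C(=O)N(Cc2cn([C@@H]3O[C@H](COC(C)=O)[C@@H](OC(C)=O)[C@H](OC(C)=O)[C@H]3OC(C)=O)nn2)c2ccccc21`, has not yet been measured in this assay. It differs from compound 2 by propyl in place of 4-(dimethylamino)phenyl on a double-bonded chain carbon bound to a double-bonded ring carbon. Within the data shown here, no measured step involves this exchange; the one step at hand, a 1.2-fold lower number from compound 1 to compound 2 (0.07 log units; within the scatter), bears on it only by showing that the two numbers so far sit close together. No move beyond the scatter is expected in either direction, and the range is set wide for want of a comparison. Compound 3 is expected to give 30000 nM in this assay, between 8000 nM and 120000 nM, an expected step of a 1.2-fold higher number from compound 2 to compound 3 (0.08 log units; within the scatter).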

Compound 3, half-maximal inhibitory concentration: 22600 nM
Beside the measured number, compound 3's estimate is 1.3-fold (0.12 log units) above it; low and high end bracket the measured number.
By their numbers in this assay, from the lowest: compounds 3, 2 and 1 (each within the scatter of the next).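

In this assay, within the data shown here, the first change of the group itself at this position, propyl in place of 4-(dimethylamino)phenyl on a double-bonded chain carbon bound to a double-bonded ring carbon, gives a 1.1-fold lower number from compound 2 to compound 3 (0.05 log units; within the scatter) and so does not move the number beyond the scatter. For compounds 2 and 3, the aromatic ring and its dimethylamino nitrogen are thus not required to keep the number in this range, and compounds 1, 2 and 3 each stay within the scatter of the next. Nothing at hand bears on this exchange or gives a reason for its size.

From the compounds shown here alone, whether a carboxylic acid, an amine or a longer chain at this position would shift the number remains open. Also open, going by these compounds, is whether phenyl without the dimethylamino group would behave like either compound 2 or compound 3.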